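From methyl to (piperidin-1-yl)methyl on a shared core

The source may hold more compounds than are shown below. What is called first, only, known or untested is meant among the compounds shown, and "the series" means these compounds.

Among the measured compounds shown here, in a functional assay on the whole organism with Mus musculus as the target (a lower number here means that less compound is needed, a higher number that more compound is needed for the effect), compound 1 `Cc1c(C)c2c(c(C)c1N)CC(C)(C)O2` gives 7.8 mg/kg and stands lowest of the three compounds measured so far. Compound 2 `Cc1c(N)cc2c(c1C)OC(C)(C)C2` gives 24.4 mg/kg and compound 3 `Cc1c(C)c2c(c(N(C)C)c1N)CC(C)(C)O2` gives 22.3 mg/kg as its number, and these two sit within the scatter of each other (a 1.1-fold lower number from compound 2 to compound 3 (0.04 log units; within the scatter)).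

Compound 4 `Cc1c(N)c(C)c2c(c1CN1CCCCC1)OC(C)(C)C2` has not been measured yet. It differs from compound 1 by a single change (piperidin-1-yl in place of hydrogen on a saturated chain carbon bound to an aromatic carbon), with piperidin-1-yl in place of hydrogen on a saturated chain carbon bound to an aromatic carbon. A methyl thus becomes (piperidin-1-yl)methyl.

For the measured compounds named here, two measured steps bear on this, as each alters a methyl of compound 1, though on an aromatic carbon. Putting hydrogen there gave a 3.1-fold higher number from compound 1 to compound 2 (0.50 log units; beyond the scatter) and putting dimethylamino there gave a 2.9-fold higher number from compound 1 to compound 3 (0.46 log units; beyond the scatter) as a similar modest rise. Going by the values given here, no step on a saturated chain carbon has been measured, so this guide is loose. A modest move to a higher number is therefore expected, estimated as a 2.6-fold higher number from compound 1 to compound 4 (0.41 log units; beyond the scatter) in this assay with wide uncertainty. Compound 4 is estimated at 20 mg/kg with 7 mg/kg to 55 mg/kg as the expected range.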

Compound 4, dose for 50% inhibition: > 50 mg/kg
Compound 4 was reported as a limit; the forecaster's own chance of this, stated with the estimate: 10%; middle value at least 2.5-fold (0.39 log units) away from the limit.
By their numbers in this assay, from the lowest: compound 1; then compounds 3 and 2 (each within the scatter of the next). At a limit, above all of these: compound 4.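

In this assay compound 4 gives > 50 mg/kg, and this is a limit of the assay, not an exact number. Hanging piperidin-1-yl on a saturated chain carbon bound to an aromatic carbon gives an at least 6.4-fold higher number from compound 1 to compound 4 (0.80 log units; beyond the scatter), the first measured step at this kind of place, since the earlier steps changed only a methyl on an aromatic carbon. So a methyl on the shared core cannot take on this six-membered ring without a clear loss in this assay, and that loss is not bounded: the printed step gives only a minimum, while the earlier changes produced modest steps with exact values.

A single group at this place cannot show whether the ring, its nitrogen or the mere lengthening of the methyl accounts for the step. An ethyl chain, an aminomethyl group or a morpholin-4-yl in the same place could separate these readings, and a carboxylic acid on that carbon would test whether any group there meets the same fate.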